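Replacing a Methoxyethyl Chain with a Hydroxymethylpropyl Chain

This account rests on a few compounds, and the source may have more. Where it says the series, first, only, none or still open, it means among the compounds named here.

Of the compounds shown here, three have been tested in an assay on CHO cells for displacement of a labelled ligand from adenosine receptor A1 (Homo sapiens), read by scintillation counting, with a stated time of 60 min, tested at 10 uM; a lower number here means less inhibition, a higher number more inhibition at the concentration tested (going by the name of the read-out). Compound 3, `COCCNC(=O)c1cc2cc(Cl)ccc2oc1=N`, gives 17%. Compound 1, `O=C(NCC(O)CO)c1cc2cc(Cl)ccc2oc1=O`, gives 21%, and compound 2, `COc1cccc2cc(C(=O)NC3CCCCC3)c(=N)oc12`, gives 40%. Compound 3 carries the lowest of the three numbers, but its gap to compound 1 is within the usual scatter of this kind of measurement, so those two cannot be told apart; only compound 2 lies clearly higher, beyond the scatter.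

Compound 4, `CCC(CO)NC(=O)c1cc2cc(Cl)ccc2oc1=N`, is not yet measured. It differs from compound 3 in one place: 1-(hydroxymethyl)propyl in place of 2-methoxyethyl on an amide-type nitrogen. The group that leaves has no hydrogen-bond donor, the one that enters has one, and both sit on an amide-type nitrogen whose other neighbour is a carbonyl carbon.

Among the measured compounds shown here, no measured pair shows this exact change, so the expectation rests on how low both compound 3 and compound 1 sit. The step from compound 3 to compound 4 is expected to be small, a number 3 percentage points higher from compound 3 to compound 4 (within the scatter), in no direction beyond the scatter. Compound 4 is therefore estimated at 20%, within 8% to 33%.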

Compound 4, a percentage reported as inhibition, at one concentration (the size of the read-out at that concentration, not a potency): 7%
Estimate against measurement, compound 4: 13 percentage points above; measured number below the stated range.
By their numbers in this assay, from the lowest: compounds 4, 3 and 1 (each within the scatter of the next, the first and the last beyond it); then compound 2.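

In this assay, among the compounds shown here, putting 1-(hydroxymethyl)propyl in place of 2-methoxyethyl on the amide-type nitrogen gives a number 10 percentage points lower from compound 3 to compound 4 (within the scatter) as the first reading of a single change at this position, with the rest of the molecule held the same. The entering group has a hydrogen-bond donor and the leaving group has none, yet this swap gives no step beyond the scatter, so these two chains cannot be told apart at the one concentration tested. Nothing in the available data bears on why the two chains read this way.

Still open, going by these compounds, is whether a chain ending in an amine or a carboxylic acid on this nitrogen would give a step beyond the scatter. Also open, on these data alone, is whether a longer chain, such as hexyl, would do so.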